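Adding a carbonyl to the side chain of compound 3

A few compounds are considered here, and "the series" means these few. Any claim that something is new, unique, unknown or untested is made for them only; others in the source may bear on it.

In a functional assay on HT-29 cells (Homo sapiens) for inhibition, read by MTT assay, with a stated time of 48 h (on this read-out lower numbers stand for stronger inhibition and higher numbers for weaker inhibition), compound 3 (`COc1cc(-c2nnc(SCc3ccc(F)cc3)n2-c2ccc(N(C)C)cc2)cc(OC)c1OC`) gives 44300 nM. Compound 1 (`COc1ccc(-n2c(SCC(=O)c3ccc(F)cc3)nnc2-c2cc(OC)c(OC)c(OC)c2)cc1`) gives 42500 nM, and these two values lie within the scatter of each other. Compound 2 (`COc1cc(-c2nnc(SCc3ccccc3)n2-c2ccc(N(C)C)cc2)cc(OC)c1OC`) reaches only a limit of the assay, > 60000 nM. Among the compounds with values here, compound 3 therefore sits level with the only other exact number in this small set.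

Compound 4 (`COc1cc(-c2nnc(SCC(=O)c3ccc(F)cc3)n2-c2ccc(N(C)C)cc2)cc(OC)c1OC`) is made from compound 3 by one structural change: (4-fluorophenyl)carbonyl in place of 4-fluorophenyl on a saturated chain carbon bound to a sulfur. In words, (4-fluorophenyl)carbonyl stands in place of 4-fluorophenyl on a saturated chain carbon bound to a sulfur. Within the data shown here, no measured step covers this change. Among the measured compounds shown here, the single step available, an at least 1.3-fold lower number from compound 2 to compound 3 (0.13 log units; that floor lies within the scatter), concerns a different change and rests on a limit, so it gives no size to carry over. No shift beyond the scatter is therefore expected, and the expected step is a 1.5-fold lower number from compound 3 to compound 4 (0.17 log units; within the scatter). Compound 4 is estimated at 30000 nM, with an expected range of 8000 nM to 60000 nM.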

Compound 4, half-maximal inhibitory concentration: 78100 nM
For compound 4 the middle estimate is 2.6-fold (0.42 log units) below the measured one, outside the stated range (above it).
By their numbers in this assay, from the lowest: compounds 1, 3 and 4 (each within the scatter of the next).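

In this assay, the change of 4-fluorophenyl to (4-fluorophenyl)carbonyl on a saturated chain carbon bound to a sulfur now has a direct reading, a 1.8-fold higher number from compound 3 to compound 4 (0.25 log units; within the scatter), so the carbonyl is not shown to move the value beyond the scatter. With that side chain held constant, dimethylamino in place of methoxy on an aromatic carbon gives a 1.8-fold higher number from compound 1 to compound 4 (0.26 log units; within the scatter), so this change is not resolved by the assay either. Compound 2 carries only a limit of the assay, and the step from it to compound 4 cannot be read: the limit of > 60000 nM in this assay, at which 1 of the 4 values shown sits.

As far as these compounds go, it remains open whether an amide or a carboxylic acid on this saturated chain carbon would give a step beyond the scatter. A longer chain at the same place is equally untested by the compounds shown.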